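The source may report more compounds than this note shows. Statements on the series, on what has been measured and on what is new or still open speak of the compounds shown alone.

The measured compounds in an ADME assay on HepG2 2.2.15 cells (Homo sapiens) for cytotoxicity; on this read-out lower numbers stand for higher toxicity in this test and higher numbers for lower toxicity in this test:

Compound 1 `O=C(Nc1ncc(Cc2ccc(Cl)cc2)s1)c1cccs1` gives > 50000 nM, which is a limit of the assay and not a number.
Compound 2 `O=C(Nc1ncc(Cc2ccc(Br)cc2)s1)c1cccs1` gives > 50000 nM, again a limit of the assay rather than a number.
Compound 3 `O=C(Nc1ncc(C(OCc2ccc(Br)cc2)c2ccccc2)s1)c1cccs1` is recorded as "not toxic" (no number reported), with no number reported at all.

Going by the values given here, compounds 1 and 2 share a core, and the one change between them is chloro in place of bromo on an aromatic carbon. In this assay this change gives a step that the two limits leave unreadable from compound 2 to compound 1, so nothing can be said about its direction or size from that pair. What holds the two values together is the limit of > 50000 nM in this assay, at which 2 of the 3 values shown sit.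

Compound 3 carries a different core, and how it differs from the core of compound 2 is not broken down here. The still unmeasured compound 4 `O=C(Nc1ncc(C(OCc2ccc(Cl)cc2)c2ccccc2)s1)c1cccs1` stands to compound 3 as compound 1 stands to compound 2: the change is chloro in place of bromo on an aromatic carbon, at the same place in the same words as before, so it is the same change on a second core.

In this assay compound 4 is therefore expected to sit where its neighbours sit, and that expectation rests on the limit of > 50000 nM in this assay, at which 2 of the 3 values shown sit, together with the unreported number for compound 3. Compound 4 is estimated at 60000 nM, with a range from 30000 nM to 200000 nM, and most likely the assay will again report only a limit.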

Compound 4, half-maximal cytotoxic concentration: "not toxic" (no number reported)
For compound 4 the study gives words and no number, so the estimate cannot be set against anything.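

Compound 3 and compound 4 are both recorded in this assay in words only, with no number for either, so no step can be read for chloro in place of bromo on this second core. The compounds shown leave open whether this change moves the read-out on either core, and the only numerical value they offer is a limit of the assay: the limit of > 50000 nM in this assay, at which 2 of the 4 values shown sit.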